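This account rests on a few compounds, and the source may have more. Where it says the series, first, only, none or still open, it means among the compounds named here.

Of the compounds shown here, two of a shared core have been measured. Compound 1 `COc1ccc(-c2nnc(SCCOc3ccc(/C=C4\SC(=O)NC4=O)cc3)[nH]2)cc1` gives 43.4% in a functional assay on the whole organism (plasma, strain Wistar) with Rattus norvegicus as the target, with a stated time of 15 days, at a dose of 100 mg/kg by the oral route; on this read-out higher numbers stand for a stronger effect at the one dose given and lower numbers for a weaker effect. Compound 2 `O=C1NC(=O)/C(=C/c2ccc(OCCSc3nnc(-c4ccccc4)o3)cc2)S1` gives 20.1% in this assay, the lower of the two numbers, and the gap to compound 1 lies beyond the usual scatter of repeated measurements. The two differ in more than one place, so their values show only what each compound does on its own.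

Compound 3 `O=C1NC(=O)/C(=C/c2ccc(OCCSc3nnc(Cc4ccccc4)o3)cc2)S1` has not yet been measured. It differs from compound 2 in one place: benzyl in place of phenyl on an aromatic carbon. For the measured compounds named here, no measured pair shows a change of this kind, so there is no step from which to read a direction. The expected step from compound 2 to compound 3, a number 1.9 percentage points higher from compound 2 to compound 3 (within the scatter), is therefore small and not beyond the scatter. For compound 3 the estimate is 22%, with a range from 5% to 42% in this assay.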

Compound 3, a percentage reported as activity, at one dose (the size of the read-out at that dose, not a potency): 23.1%
Estimate against measurement, compound 3: 1.1 percentage points below, and the stated range covers the measured number.
By their numbers in this assay, from the lowest: compounds 2 and 3 (each within the scatter of the next); then compound 1.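

In this assay, the change at this position, on an aromatic carbon of the five-membered aromatic ring with 2 nitrogen and 1 oxygen, gives a number 3 percentage points higher from compound 2 to compound 3 (within the scatter). For the compounds shown here, this is the first step read at a single place, which compounds 1 and 2, differing in more than one place, could not supply: with benzyl in place of phenyl, the two values stay within the scatter of each other.

The compounds shown leave open what an amine, a carboxylic acid or a longer chain such as phenethyl would do on this same carbon. They also leave open whether benzyl in place of phenyl would give a similar step on the core of compound 1. Nothing available here offers an explanation for this result.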